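This account rests on a few compounds, and the source may have more. Where it says the series, first, only, none or still open, it means among the compounds named here.

Going by the values given here, in an assay on HEK293 cells for displacement of a labelled ligand from NPC1-like intracellular cholesterol transporter 1 (Homo sapiens) (on this read-out lower numbers stand for stronger inhibition and higher numbers for weaker inhibition), compound 3 `CC(C)(C)c1ccc(C(=O)N2CCC3(CC2)C(=O)N(CC(=O)NCCCN)CN3c2ccccc2)cc1` gives 4200 nM, the lowest of the three numbers so far. Compound 2 `CC(C)(C)c1ccc(C(=O)N2CCC3(CC2)C(=O)N(CC(=O)N2CCCCC2CCO)CN3c2ccccc2)cc1` gives 6100 nM in this assay, and compound 1 `CC(C)(C)c1ccc(C(=O)N2CCC3(CC2)C(=O)N(CC(=O)N2CCN(S(C)(=O)=O)CC2)CN3c2ccccc2)cc1` gives 19000 nM. The two larger steps both start from compound 1: a 3.1-fold lower number from compound 1 to compound 2 (0.49 log units; beyond the scatter) and a 4.5-fold lower number from compound 1 to compound 3 (0.66 log units; beyond the scatter). The step of a 1.5-fold lower number from compound 2 to compound 3 (0.16 log units; within the scatter) separates the two cyclic and open-chain amide groups by no more than the scatter allows.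

Compound 4 `CC(C)(C)c1ccc(C(=O)N2CCC3(CC2)C(=O)N(CC(=O)N2CCC(O)CC2)CN3c2ccccc2)cc1` carries the change (4-hydroxypiperidin-1-yl in place of (3-aminopropyl)amino on a carbonyl carbon). The group that enters is, like that of compound 2, a six-membered non-aromatic ring bearing a hydroxyl, so the step of a 1.5-fold lower number from compound 2 to compound 3 (0.16 log units; within the scatter) is the closest guide, while the step of a 4.5-fold lower number from compound 1 to compound 3 (0.66 log units; beyond the scatter) shows that a different six-membered ring on the same carbonyl carbon can give a clearly higher number. The expected outcome for compound 4 is therefore a small step toward a higher number, a 1.5-fold higher number from compound 3 to compound 4 (0.19 log units; within the scatter), not clearly beyond the scatter. Compound 4 is estimated at 6500 nM in this assay, with a range from 2500 nM to 17000 nM.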

Compound 4, half-maximal inhibitory concentration: 4700 nM
Compound 4: the middle estimate sits 1.4-fold (0.14 log units) above what was measured; the measured number falls inside the stated range.
By their numbers in this assay, from the lowest: compounds 3, 4 and 2 (each within the scatter of the next); then compound 1.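

In this assay a ring can take the place of the open chain on this carbonyl carbon without a readable difference: 4-hydroxypiperidin-1-yl for (3-aminopropyl)amino gives a 1.1-fold higher number from compound 3 to compound 4 (0.05 log units; within the scatter) and, set against 2-(2-hydroxyethyl)piperidin-1-yl, gives a 1.3-fold lower number from compound 2 to compound 4 (0.11 log units; within the scatter). Among the four compounds, only the 4-(methylsulfonyl)piperazin-1-yl group of compound 1 stands apart from the others, and the new compound repeats this with a 4.0-fold lower number from compound 1 to compound 4 (0.61 log units; beyond the scatter). No measurement at hand accounts for this grouping.

The compounds shown leave open how plain piperidin-1-yl would read here, which would test whether the hydroxyl of 4-hydroxypiperidin-1-yl matters at all. They also leave open how a carboxylic acid on the piperidine ring, or a chain longer than (3-aminopropyl)amino, would read on the same carbonyl carbon.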